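The compounds below may be only part of what the source reports. "The series", "measured", "known", "first", "only" and "open" are said of these compounds alone.

Compound 1 (`COc1ccc(S(=O)(=O)N2CCc3cccc(-c4cccc(F)c4)c32)cc1`) and compound 2 (`COc1ccc(S(=O)(=O)N2CCc3cccc(-c4ccccc4)c32)cc1`) share one core. In a functional assay on NCI-H460 cells (Homo sapiens) for inhibition, with a stated time of 72 h (on this read-out higher numbers stand for weaker inhibition and lower numbers for stronger inhibition), compound 1 gives 167 nM and compound 2 gives 213 nM with the two lying within the scatter of each other, so compound 2 cannot be told apart from the only other measured point.

The next entry is compound 3 (`COc1ccc(S(=O)(=O)N2CCc3cccc(-c4ccc(O)cc4)c32)cc1`). Its change from compound 2 is hydroxy in place of hydrogen on an aromatic carbon, para to a large group (hydroxy in place of hydrogen on an aromatic carbon), which reads as phenyl to 4-hydroxyphenyl.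

Within the data shown here, one measured step bears on this, and only loosely (a 1.3-fold higher number from compound 1 to compound 2 (0.11 log units; within the scatter)). It also concerns a substituent on an aromatic carbon, but that substituent is fluoro, not hydroxy, and the step stays within the scatter. Among the measured compounds shown here, no measured compound carries a hydroxy, so the direction remains open. The expected step (a 1.3-fold higher number from compound 2 to compound 3 (0.12 log units; within the scatter)) is no larger than the scatter, and the range is kept wide on both sides.

In this assay compound 3 is estimated at 280 nM (expected range 90 nM to 850 nM) on this thin evidence.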

Compound 3, half-maximal inhibitory concentration: 114 nM
The estimate for compound 3 lay 2.5-fold (0.39 log units) above the measured number; the range from low to high includes it.
By their numbers in this assay, from the lowest: compounds 3, 1 and 2 (each within the scatter of the next).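

Working notes on the series: in this assay, placing a hydroxy on the aromatic carbon para to a large group gives a 1.9-fold lower number from compound 2 to compound 3 (0.27 log units; within the scatter), so this first hydroxy in the series leaves the number indistinguishable from that of the unsubstituted phenyl. The exchange of the whole aryl group gives a 1.5-fold lower number from compound 1 to compound 3 (0.17 log units; within the scatter), so 4-hydroxyphenyl and 3-fluorophenyl also cannot be told apart, and compounds 1, 2 and 3 now form one band despite carrying a hydrogen-bond donor and acceptor in compound 3 that compound 2 lacks. This extends the earlier reading from a fluoro substituent to a hydroxy, showing that the aryl group can carry either one with no readable effect on this read-out, and nothing available explains this flat result.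

The compounds shown leave open whether an amine, a carboxylic acid or a longer chain in the same place would stay inside this band or move clearly out of it. Among these compounds, with every step so far inside the scatter, they also give no direction for substitution on this aryl group, and a larger substituent such as a morpholine ring would be needed to test its limits.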